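Swapping 3-hydroxypyrrolidin-1-yl for 3-carboxypyrrolidin-1-yl at the limit

This account rests on a few compounds, and the source may have more. Where it says the series, first, only, none or still open, it means among the compounds named here.

Compound 1 `COc1ccc(/C=C\c2cc(OC)c(OC)c(OC)c2)cc1OCc1ccc(CN2CCCC[C@@H]2C(=O)O)cc1` gives > 10000 nM (a limit)
Compound 2 `COc1ccc(/C=C\c2cc(OC)c(OC)c(OC)c2)cc1OCc1ccc(CN2CC[C@H](O)C2)cc1` gives > 10000 nM (a limit)

In a functional assay on B16-F10 cells (Mus musculus) for antiproliferative activity, read by CCK-8 assay, with a stated time of 48 h (a higher number here means a weaker inhibitor, a lower number a stronger inhibitor), compound 2 gives > 10000 nM as a limit and not a number. For the measured compounds named here, the evidence so far is the limit of > 10000 nM in this assay, at which 2 of the 2 values shown sit, and the only measured step is a step that the two limits leave unreadable from compound 1 to compound 2 so no size can be drawn from it. Compound 3 `COc1ccc(/C=C\c2cc(OC)c(OC)c(OC)c2)cc1OCc1ccc(CN2CC[C@@H](C(=O)O)C2)cc1` brings the change 3-carboxypyrrolidin-1-yl in place of 3-hydroxypyrrolidin-1-yl on a saturated chain carbon bound to an aromatic carbon on a saturated chain carbon bound to an aromatic carbon. Compound 1 carries 2-carboxypiperidin-1-yl and gives > 10000 nM as a limit. A limit is therefore expected again, with a step that the limit leaves unreadable from compound 2 to compound 3 as the estimated step and no direction that the data can fix. For compound 3 the estimate is 15000 nM with an expected range from 4000 nM to 50000 nM in this measurement.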

Compound 3, half-maximal inhibitory concentration: > 10000 nM
Compound 3: no number, only a limit (the forecaster's own chance of this, stated with the estimate: 85%); the middle value is on the limit's open side.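

In this assay, for the compounds shown here, compound 1, compound 2 and compound 3 each give only a limit, so no step among them can be read. From the compounds shown here alone, how far each compound lies beyond its limit, and whether any other group at this place would give a real number, stays open.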